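Swapping Methyl for Bromo on a Benzyl Group

The source may hold more compounds than are shown below. What is called first, only, known or untested is meant among the compounds shown, and "the series" means these compounds.

In an assay on isolated protein for inhibition of Amine oxidase [flavin-containing] A (Homo sapiens), read by fluorescence, with stated times of 15 min and 20 min (a higher number here means a weaker inhibitor, a lower number a stronger inhibitor), compound 2 `Cc1ccc(CN2CCC(CCNC(=O)/C=C/c3cc(C(C)(C)C)c(O)c(C(C)(C)C)c3)CC2)cc1` gives 70100 nM. Compound 1 `CC(C)(C)c1cc(/C=C/C(=O)NC2CCN(Cc3ccccc3)CC2)cc(C(C)(C)C)c1O` gives 42500 nM in this assay, a number within the usual scatter of that of compound 2, so the two stand together as weak inhibitors. Compound 3 `CC(C)(C)c1cc(/C=C/C(=O)NCCC2CCN(Cc3ccc(Br)cc3)CC2)cc(C(C)(C)C)c1O` has not yet been measured in this assay. It differs from compound 2 in one place: bromo in place of methyl on an aromatic carbon. Among the measured compounds shown here, no measured pair shows this kind of exchange, so there is no step to lean on. The change is expected to leave the number roughly where it is, within the scatter, as a step of a 1.2-fold lower number from compound 2 to compound 3 (0.07 log units; within the scatter). Compound 3 is expected to give about 60000 nM in this assay, with a range from 25000 nM to 150000 nM.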

Compound 3, half-maximal inhibitory concentration: 73200 nM
The estimate for compound 3 lay 1.2-fold (0.09 log units) below the measured number, and the stated range covers the measured number.
By their numbers in this assay, from the lowest: compounds 1, 2 and 3 (each within the scatter of the next).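

In this assay the exchange of 4-methylbenzyl for 4-bromobenzyl gives a 1.0-fold higher number from compound 2 to compound 3 (0.02 log units; within the scatter) and so leaves compound 3 level with compound 2, still a weak inhibitor. Among the compounds shown here, at this position on the aromatic ring, methyl and bromo therefore read alike, which no earlier pair could show. Nothing available explains this result. Still open, as far as these compounds go, is whether an amine or a carboxylic acid at this same position would shift the number beyond the scatter. A hydrogen there, with the rest of compound 2 kept, also remains to be compared.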